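Methyl for Methoxy: Expected Cytotoxicity of Compound 4

A few compounds are considered here, and "the series" means these few. Any claim that something is new, unique, unknown or untested is made for them only; others in the source may bear on it.

Compound 1 `O=C(NCCOC(=S)Nc1ccc(F)cc1)c1cccnc1`: > 800000 nM
Compound 2 `O=C(NCCOC(=S)Nc1ccccc1)c1cccnc1`: > 800000 nM
Compound 3 `COc1ccc(NC(=S)OCCNC(=O)c2cccnc2)cc1`: > 800000 nM

In an ADME assay on RAW264.7 cells (Mus musculus) for cytotoxicity, read by MTT assay, with a stated time of 48 h (on this read-out lower numbers stand for stronger inhibition and higher numbers for weaker inhibition), each of these three values is a limit of the assay, not a measured number. All three sit at the limit of > 800000 nM in this assay, at which 3 of the 3 values shown sit. Compound 3 therefore stands only at a limit, and nothing separates it from compound 1 or compound 2 on the numbers shown. The steps a step that the two limits leave unreadable from compound 1 to compound 2, a step that the two limits leave unreadable from compound 1 to compound 3 and a step that the two limits leave unreadable from compound 2 to compound 3 are accordingly unreadable in size, though each shows that a change on the aromatic carbon left the read-out at the same limit.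

Compound 4 `Cc1ccc(NC(=S)OCCNC(=O)c2cccnc2)cc1` differs from compound 3 in one place: methyl in place of methoxy on an aromatic carbon. The three measured steps all concern swaps at this same position, and none moved the read-out off the limit. For compound 4 in this assay, no step beyond the usual scatter is therefore expected, and a further limit is the most likely outcome. The step that the limit leaves unreadable from compound 3 to compound 4 is estimated to be flat. Compound 4 is expected to give about 1000000 nM, between 500000 nM and 3000000 nM.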

Compound 4, half-maximal inhibitory concentration: > 800000 nM
Compound 4: only a limit was reported (the forecaster's own chance of this, stated with the estimate: 85%); the middle value lies beyond the limit too.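

Compound 4 reports only a limit, as do compound 1, compound 2 and compound 3, so no step among them can be read in size: the limit of > 800000 nM in this assay, at which 4 of the 4 values shown sit.

The compounds shown leave open whether any swap on this aromatic carbon changes the read-out in this assay at all.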